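The source may report more compounds than this note shows. Statements on the series, on what has been measured and on what is new or still open speak of the compounds shown alone.

Measured so far:
compound 1 `CN[C@@H]1C[C@@H](c2c(OC)cccc2OC)N(Cc2ccc(OC(F)(F)F)cc2)C1=O`; in a functional assay on CHO cells for antagonist activity at Orexin receptor type 2 (Homo sapiens), read by FLIPR and calcium flux (on this read-out higher numbers stand for weaker inhibition and lower numbers for stronger inhibition), compound 1 gives 5810 nM
compound 2 `COc1cccc(OC)c1[C@@H]1C[C@H](Cl)C(=O)N1Cc1ccc(OC(F)(F)F)cc1`; in this assay compound 2 gives 41 nM
compound 3 `COc1cccc(OC)c1[C@@H]1C[C@@H](N(C)C)C(=O)N1Cc1ccc(OC(F)(F)F)cc1`; in this assay compound 3 reaches only > 10000 nM, a limit of the assay, not a number the limit of > 10000 nM in this assay, at which 1 of the 3 values shown sits.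

Compound 3 thus stands at the limit of this assay; of the three values shown it is the only one there. Compound 4 `COc1cccc(OC)c1[C@@H]1C[C@@H](Cl)C(=O)N1Cc1ccc(OC(F)(F)F)cc1` differs from compound 3 by chloro in place of dimethylamino on a saturated ring carbon. Going by the values given here, the single measured step, an at least 1.7-fold higher number from compound 1 to compound 3 (0.23 log units; that floor lies within the scatter), concerns methylation of an amine nitrogen and does not cover exchange of the amine for chloro, so it gives no direct guide. Compound 2 carries chloro on that saturated ring carbon in the opposite configuration and in this assay compound 2 gives 41 nM. A step toward a lower number is expected, of size an at least 25-fold lower number from compound 3 to compound 4 (1.39 log units; beyond the scatter), with wide uncertainty. Compound 4 is therefore estimated at 400 nM, between 50 nM and 4000 nM.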

Compound 4, half-maximal inhibitory concentration: 563 nM
The estimate for compound 4 lay 1.4-fold (0.15 log units) below the measured number; the range from low to high includes it.
By their numbers in this assay, from the lowest: compound 2; then compound 4; then compound 1. At a limit, above all of these: compound 3.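

In this assay, chloro in place of methylamino at this saturated ring carbon gives a 10-fold lower number from compound 1 to compound 4 (1.01 log units; beyond the scatter). The step of an at least 17-fold lower number from compound 3 to compound 4 (1.24 log units; beyond the scatter) is only a floor, as compound 3 stands at a limit: the limit of > 10000 nM in this assay, at which 1 of the 4 values shown sits. Configuration at this carbon also matters for chloro, with a 14-fold higher number from compound 2 to compound 4 (1.14 log units; beyond the scatter), a step that comes from configuration alone: the fact that compounds 2 and 4 differ only in the configuration as drawn

From the compounds shown here alone, whether a hydroxyl, a fluorine or a nitrile at this carbon would track chloro stays open. So does whether the methylamino and dimethylamino groups would show a similar configuration step.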